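A furan takes the place of 2-vinylphenyl

The source may hold more compounds than are shown below. What is called first, only, known or untested is meant among the compounds shown, and "the series" means these compounds.

In a functional assay on A549 cells (Homo sapiens) for cytotoxicity (on this read-out higher numbers stand for an effect only at larger amounts of compound and lower numbers for an effect already at smaller amounts), compound 1 (`COC1=C(C)C(=O)/C(=C(O)/C=C/c2c(C)cccc2C)C(=O)C1(C)C`) gives 8.3 ug/mL and compound 2 (`C=Cc1ccccc1/C=C/C(O)=C1/C(=O)C(C)=C(OC)C(C)(C)C1=O`) gives 2.2 ug/mL as the lower of the two numbers. Compound 3 (`COC1=C(C)C(=O)/C(=C(O)/C=C/c2ccco2)C(=O)C1(C)C`) carries furan-2-yl in place of 2-vinylphenyl on a double-bonded chain carbon bound to a double-bonded chain carbon. Among the compounds with values here, the only measured step at this place, 2-vinylphenyl in place of 2,6-dimethylphenyl, is modest (a 3.8-fold lower number from compound 1 to compound 2 (0.58 log units; beyond the scatter)). Within the data shown here, no compound with furan-2-yl has a number yet, so this step is only a rough guide. Going by compound 1 at 8.3 ug/mL as the only other number, a return towards it is expected once 2-vinylphenyl leaves. The expected change in this assay is a 2.7-fold higher number from compound 2 to compound 3 (0.44 log units; beyond the scatter) and lies on the side of higher numbers. Compound 3 is estimated at 6 ug/mL with an expected range from 2.5 ug/mL to 15 ug/mL for repeated measurements.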

Compound 3, concentration for half-maximal effect: 10 ug/mL
Estimate against measurement, compound 3: 1.7-fold (0.22 log units) below, and the stated range covers the measured number.
By their numbers in this assay, from the lowest: compound 2; then compounds 1 and 3 (each within the scatter of the next).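

In this assay, the lower number of compound 2 does not carry over to furan-2-yl, with a 4.5-fold higher number from compound 2 to compound 3 (0.66 log units; beyond the scatter). Against 2,6-dimethylphenyl the picture differs, with a 1.2-fold higher number from compound 1 to compound 3 (0.08 log units; within the scatter), so on a double-bonded chain carbon bound to a double-bonded chain carbon a five-membered aromatic ring with a hetero atom and a six-membered aromatic ring of carbon only read alike, and among these three compounds only 2-vinylphenyl stands apart. No measured evidence is available to explain what sets 2-vinylphenyl apart from the other two groups.

The compounds shown leave open whether the lower number of compound 2 goes with the vinyl double bond itself, a question that a 2-ethylphenyl group at this place would address. They also leave open how an aminophenyl group would read here.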